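From 4-hydroxyphenyl to amino: one step awaiting measurement

A few compounds are considered here, and "the series" means these few. Any claim that something is new, unique, unknown or untested is made for them only; others in the source may bear on it.

Of the compounds shown here, three with a shared core have been measured in a functional assay on HCT-116 cells (Homo sapiens) for cytotoxicity, read by sulforhodamine B assay, with a stated time of 24 h; on this read-out higher numbers stand for weaker inhibition and lower numbers for stronger inhibition. Compound 2 `O=C1Nc2ccc(S(=O)(=O)N3CCOCC3)cc2/C1=N/c1ccc(O)cc1` gives 27300 nM and compound 3 `COc1ccc(-c2c(C#N)c(N)n(/N=C3\C(=O)Nc4ccc(S(=O)(=O)N5CCOCC5)cc43)c(=O)c2C#N)cc1` gives 18100 nM, a gap within the scatter, so the two cannot be told apart. Compound 1 `N=c1oc2ccccc2cc1C(=O)N/N=C1\C(=O)Nc2ccc(S(=O)(=O)N3CCOCC3)cc21` gives 6750 nM, and compound 2 stands at a higher number than this, with the gap beyond the scatter.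

Compound 4 `N/N=C1\C(=O)Nc2ccc(S(=O)(=O)N3CCOCC3)cc21` differs from compound 2 in one place: amino in place of 4-hydroxyphenyl on a double-bonded nitrogen. Among the compounds with values here, no measured pair isolates this change. The group on that nitrogen differs in all three measured compounds, yet their values in this assay run only from compound 1 at 6750 nM to compound 2 at 27300 nM. The expected 1.8-fold lower number from compound 2 to compound 4 (0.26 log units; within the scatter) points to a lower number but stays within the scatter. For compound 4 the estimated value is 15000 nM, with an expected range from 5000 nM to 45000 nM.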

Compound 4, half-maximal inhibitory concentration: 36300 nM
Compound 4: the middle estimate sits 2.4-fold (0.38 log units) below what was measured; measured number inside the range.
By their numbers in this assay, from the lowest: compound 1; then compounds 3, 2 and 4 (each within the scatter of the next).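

In this assay, putting amino in place of 4-hydroxyphenyl on the double-bonded nitrogen gives a 1.3-fold higher number from compound 2 to compound 4 (0.12 log units; within the scatter) and so the two compounds cannot be told apart. Within the data shown here, this is the first pair to isolate a change at this place, and it shows that a group with a six-membered aromatic ring and a group with no ring cannot be separated here, though the change removes most of the heavy atoms of the group. Nothing measured here accounts for this result.

The compounds shown leave open how a group such as acetylamino or a dimethylamino group would read at this place in this assay. They also leave open whether a longer alkyl chain or a carboxylic acid on the phenyl ring of compound 2 would move the number beyond the scatter.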